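Chloro for butyl on the amide chain of compound 2

This account rests on a few compounds, and the source may have more. Where it says the series, first, only, none or still open, it means among the compounds named here.

Measured so far:
compound 1 `CCCCCC(=O)Nc1ccc(S(=O)(=O)Oc2ccccc2C(C)C)cc1` — 5300 nM
compound 2 `CCCCCC(=O)Nc1ccc(S(=O)(=O)Oc2ccccc2I)cc1` — 10000 nM
compound 3 `CC(C)c1ccccc1OS(=O)(=O)c1ccc(NC(=O)C(C)(C)C)cc1` — 6500 nM

In a functional assay on MCF7 cells (Homo sapiens) for antiproliferative activity, read by sulforhodamine B assay, with a stated time of 48 h (a lower number here means a stronger inhibitor, a higher number a weaker inhibitor), compound 2 gives 10000 nM, the highest of the three numbers, but its gaps to compound 3 and compound 1 both fall within the scatter, so no order among the three can be read. The step from compound 1 to compound 2 was a 1.9-fold higher number from compound 1 to compound 2 (0.28 log units; within the scatter), and the step from compound 1 to compound 3 was a 1.2-fold higher number from compound 1 to compound 3 (0.09 log units; within the scatter).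

Compound 4 `O=C(CCl)Nc1ccc(S(=O)(=O)Oc2ccccc2I)cc1` differs from compound 2 by chloro in place of butyl on a saturated chain carbon bound to a carbonyl carbon. Going by the values given here, only the step from compound 1 to compound 3 touches the acyl part, and it stayed within the scatter; no measured step exchanges a chain for chloro. The expectation for this assay is therefore a step of a 1.4-fold lower number from compound 2 to compound 4 (0.15 log units; within the scatter), with wide uncertainty.

Compound 4 is estimated at 7000 nM in this assay, within a range of 2500 nM to 20000 nM.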

Compound 4, half-maximal inhibitory concentration: 2500 nM
The estimate for compound 4 lay 2.8-fold (0.45 log units) above the measured number; measured number inside the range.
By their numbers in this assay, from the lowest: compound 4; then compounds 1, 3 and 2 (each within the scatter of the next).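

In this assay, going by these compounds alone, chloro in place of butyl on a saturated chain carbon bound to a carbonyl carbon gives a 4.0-fold lower number from compound 2 to compound 4 (0.60 log units; beyond the scatter), the first step beyond the scatter. The earlier change on the acyl side, tert-butyl in place of pentyl on a carbonyl carbon, gave only a 1.2-fold higher number from compound 1 to compound 3 (0.09 log units; within the scatter), so this part of the molecule is now shown to respond to the group it carries, though on the evidence of one pair with the iodo group. Nothing shown bears on the reason for this step.

A chain ending in a methyl, bromo or amine group would be needed to tell the contribution of the chloro group from that of the shorter chain. Also open, from the compounds shown here alone, is whether the same exchange gives a step of like size on compound 1, which carries isopropyl in place of iodo.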